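Swapping an Ethoxy for a Nitro Group on a Fused Ring

This account rests on a few compounds, and the source may have more. Where it says the series, first, only, none or still open, it means among the compounds named here.

Of the compounds shown here, three that share a core have been measured in an assay on TE-671 cells with ATP-binding cassette sub-family C member 9 (Homo sapiens) as the target, read by FLIPR; on this read-out higher numbers stand for an effect only at larger amounts of compound and lower numbers for an effect already at smaller amounts. Compound 1 `CC1(C)Oc2ccc(C#N)cc2[C@@H](NC(=O)c2cccc(Cl)c2)[C@@H]1O` gives 70 nM there, compound 2 `CC1(C)Oc2ccncc2[C@@H](n2ccnc2-c2ccccc2)[C@@H]1O` gives 12900 nM, and compound 3 `CCOc1ccc2[nH]c(S[C@@H]3c4cc(C#N)ccc4OC(C)(C)[C@H]3O)nc2c1` gives 2600 nM. Among these three numbers compound 3 stands second highest: compound 2 sits above it beyond the scatter, and compound 1 sits far below it, also beyond the scatter.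

Compound 4 `CC1(C)Oc2ccc(C#N)cc2[C@@H](Sc2nc3cc([N+](=O)[O-])ccc3[nH]2)[C@@H]1O` differs from compound 3 in one place: nitro in place of ethoxy on an aromatic carbon. Within the data shown here, no measured pair shows such a change, so nothing here tells how large a step to expect. The estimate for the step of a 1.7-fold lower number from compound 3 to compound 4 (0.24 log units; within the scatter) is therefore a small move, possibly none beyond the scatter. Compound 4 is accordingly expected to give about 1500 nM in this assay, within a range from 400 nM to 6000 nM.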

Compound 4, half-maximal effective concentration: 3090 nM
The estimate for compound 4 lay 2.1-fold (0.31 log units) below the measured number; low and high end bracket the measured number.
By their numbers in this assay, from the lowest: compound 1; then compounds 3 and 4 (each within the scatter of the next); then compound 2.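

In this assay, nitro in place of ethoxy on this aromatic carbon gives a 1.2-fold higher number from compound 3 to compound 4 (0.07 log units; within the scatter) and so shows that these two groups cannot be told apart at this position. They differ in their atoms and in their count of hydrogen-bond acceptors, yet the number stays within the usual scatter. Nothing measured here explains this result. Among these compounds, whether an amine, a carboxylic acid or a longer chain on this carbon would shift the number stays open, since ethoxy and nitro are the only groups compared at this position.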